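The source may report more compounds than this note shows. Statements on the series, on what has been measured and on what is new or still open speak of the compounds shown alone.

Compound 1, with the structure `CC1(C)CC(=O)C2=C(C1)OC(=O)C(NC(=O)c1ccccc1)C2c1ccco1`, was examined in a functional assay on SW 1116 cells (Homo sapiens) for cytotoxicity, read by MTT assay, with a stated time of 24 h, tested at 1 ug/mL (a higher number here means a weaker effect of the compound at the concentration tested, a lower number a stronger effect), and there compound 1 gives 67.7%. A second member of the series, compound 2, with the structure `O=C1CCCC2=C1C(c1ccco1)C(NC(=O)c1ccccc1)C(=O)O2`, was run in the same test, and compound 2 gives 97.9%. Of the two numbers, compound 1 holds the lower one, and the gap to compound 2 lies beyond the usual scatter of such measurements; no single-point comparison between the two is drawn here, so only the two values themselves are stated.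

Compound 3, with the structure `CC1(C)CC(=O)C2=C(C1)OC(=O)C(NC(=O)c1ccccc1)C2c1ccc([N+](=O)[O-])cc1`, has not yet been measured. Relative to compound 1 it carries the change (4-nitrophenyl in place of furan-2-yl on a saturated ring carbon), a 4-nitrophenyl group in place of the furan-2-yl group on a saturated ring carbon of the shared core. For the measured compounds named here, no measured pair in this set shows what such an exchange does in this assay, so the expectation rests on compound 1 alone. The step of a number 7.3 percentage points higher from compound 1 to compound 3 (within the scatter) is estimated to be small, if anything toward a higher number, and not beyond the scatter. Compound 3 is therefore expected to give about 75%, within a range from 50% to 97%.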

Compound 3, a percentage reported as activity, at one concentration (the size of the read-out at that concentration, not a potency): 73.4%
For compound 3 the middle estimate is 1.6 percentage points above the measured one; low and high end bracket the measured number.
By their numbers in this assay, from the lowest: compounds 1 and 3 (each within the scatter of the next); then compound 2.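

In this assay, for the compounds shown here, the exchange of furan-2-yl for 4-nitrophenyl on the saturated ring carbon gives the first readable step at this position, a number 5.7 percentage points higher from compound 1 to compound 3 (within the scatter). This position of the shared core therefore accepts a six-membered aromatic ring of carbon only, carrying more heavy atoms, in place of a five-membered aromatic ring with one hetero atom, with no step beyond the scatter at the single concentration tested. The measurements on hand offer no explanation for this result.

Going by these compounds, it remains open whether the same exchange would give a similar step on the core of compound 2, and whether compound 1 and compound 3 would stay this close at other concentrations. Equally open, on these data alone, is what this position would give with a phenyl ring bearing an amine or a carboxylic acid in place of the nitro group, or with a saturated group such as a cyclohexyl ring or a longer alkyl chain in place of the aromatic ring.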